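Working notes: 2-hydroxyphenyl to 2-chlorophenyl

The source may report more compounds than this note shows. Statements on the series, on what has been measured and on what is new or still open speak of the compounds shown alone.

Measured so far in a functional assay on HeLa cells (Homo sapiens) for cytotoxicity, read by MTT assay, with a stated time of 48 h (on this read-out lower numbers stand for stronger inhibition and higher numbers for weaker inhibition), for the series:
- compound 1 `COc1cc(/C=C/C(=O)C2=C(/C=C/c3ccc(O)c(OC)c3)NC(=O)NC2c2ccccc2)ccc1O` gives 100000 nM
- compound 2 `COc1cc(/C=C/C(=O)C2=C(/C=C/c3ccc(O)c(OC)c3)NC(=O)NC2c2ccc(C)cc2)ccc1O` gives 100000 nM
- compound 3 `COc1cc(/C=C/C(=O)C2=C(/C=C/c3ccc(O)c(OC)c3)NC(=S)NC2c2ccccc2O)ccc1O` gives 25000 nM

Compound 3 holds the lowest of the three numbers, and compound 1 and compound 2 both lie above it by more than the scatter. Compound 3 differs from each of them in more than one place, so no single change can be read from those gaps.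

Next is compound 4 `COc1cc(/C=C/C(=O)C2=C(/C=C/c3ccc(O)c(OC)c3)NC(=S)NC2c2ccccc2Cl)ccc1O` with chloro in place of hydroxy on an aromatic carbon, ortho to a large group. The change counts as chloro in place of hydroxy on an aromatic carbon and turns 2-hydroxyphenyl into 2-chlorophenyl.

Within the data shown here, only one measured step is available for comparison: no change at the digits printed from compound 1 to compound 2 (within the scatter) for methyl in place of hydrogen on an aromatic carbon. Among the measured compounds shown here, it is a different exchange, and no measured step removes a hydroxy group alone, so the direction remains open. No step beyond the scatter is therefore expected in this assay, with only a slight lean toward a higher number.

The expected step is a 1.4-fold higher number from compound 3 to compound 4 (0.15 log units; within the scatter) on this estimate. For compound 4 the estimated value is 35000 nM with an expected range from 12000 nM to 100000 nM as the working span.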

Compound 4, half-maximal inhibitory concentration: 50000 nM
For compound 4 the middle estimate is 1.4-fold (0.15 log units) below the measured one, and the stated range covers the measured number.
By their numbers in this assay, from the lowest: compounds 3, 4, 1 and 2 (each within the scatter of the next, the first and the last beyond it).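

In this assay, chloro in place of hydroxy on an aromatic carbon, ortho to a large group, gives a 2.0-fold higher number from compound 3 to compound 4 (0.30 log units; within the scatter), the first step read at this position. Among these compounds, the hydroxy group, counted with 1 hydrogen-bond donor and 1 hydrogen-bond acceptor, can therefore be exchanged here for chloro, counted with neither, without a step beyond the scatter, whereas the only earlier step was methyl in place of hydrogen, a different exchange on an aromatic carbon. No measurement of any property of these groups is available to bear on this result.

From the compounds shown here alone, the gaps from compound 3 and compound 4 to compound 1 and compound 2 cannot be read, as each of these pairs differs in more than one place, so the share of the thiocarbonyl and of the ortho group in those gaps remains open. Also open, going by these compounds, is whether the same position would stay within the scatter with hydrogen, methoxy, an amine or a carboxylic acid in place of the hydroxy group of compound 3.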